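Inverting one stereocentre of compound 2

A few compounds are considered here, and "the series" means these few. Any claim that something is new, unique, unknown or untested is made for them only; others in the source may bear on it.

Series values in a functional assay on HeLa cells (Homo sapiens) for cytotoxicity, read by MTT assay, with a stated time of 48 h; on this read-out lower numbers stand for stronger inhibition and higher numbers for weaker inhibition:
- compound 1 `CCOC(=O)[C@@]1(C(=O)Nc2ccccc2Cl)C[C@@H]1c1cc(OC)c(OC)c(OC)c1`: > 100000 nM (a limit)
- compound 2 `CCOC(=O)[C@@]1(C(=O)NCc2ccc(C)cc2)C[C@H]1c1cc(OC)c(OC)c(OC)c1`: 19700 nM
- compound 3 `COc1cc([C@@H]2C[C@@]2(CO)C(=O)NCc2ccc(C)cc2)cc(OC)c1OC`: 41200 nM

Compound 1 stands at > 100000 nM, which is a limit of the assay and not a number. Of the two numerical values, the lower belongs to compound 2 at 19700 nM. Hydroxymethyl in place of ethoxycarbonyl gives a 2.1-fold higher number from compound 2 to compound 3 (0.32 log units; beyond the scatter), a modest change beyond the scatter.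

The next compound to be measured is compound 4 `CCOC(=O)[C@@]1(C(=O)NCc2ccc(C)cc2)C[C@@H]1c1cc(OC)c(OC)c(OC)c1`. Its difference from compound 2 is the two compounds have the same atoms and bonds and differ only in configuration as drawn: 1 of 2 stereo elements differ; a stereocentre at a saturated ring carbon is drawn S in compound 2 and R in compound 4. No atom or bond enters or leaves, so the change is purely one of configuration as drawn.

Among the compounds with values here, no measured step changes configuration. Within the data shown here, the only measured step is a 2.1-fold higher number from compound 2 to compound 3 (0.32 log units; beyond the scatter), which bears on this question only as a guide to size, since it concerns a different kind of change. With compound 2 at the low end on 19700 nM, a move in this assay towards a higher number is expected, though a move the other way is not excluded. The estimated step is a 1.9-fold higher number from compound 2 to compound 4 (0.29 log units; within the scatter), and it remains uncertain. Compound 4 is expected at 38000 nM, with an estimated range of 12000 nM to 100000 nM.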

Compound 4, half-maximal inhibitory concentration: > 100000 nM
Compound 4 ended at the assay's limit; the forecaster's own chance of this, stated with the estimate: 25%; middle value at least 2.6-fold (0.42 log units) away from the limit.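

Inverting the stereocentre at the saturated ring carbon gives an at least 5.0-fold higher number from compound 2 to compound 4 (0.70 log units; beyond the scatter) in this assay, the first measured step in the series that changes configuration alone. For compound 4, > 100000 nM is a limit of the assay and not a number, so only a lower bound on the size of this step can be read. The configuration at this carbon therefore has a measurable bearing on the read-out with ethoxycarbonyl and 4-methylbenzyl amide held constant, and the step can be assigned to configuration as drawn because nothing else separates the pair: the fact that compounds 2 and 4 differ only in the configuration as drawn.

The step between compound 1 and compound 4 cannot be read, and the upper end of the series offers no ordering: the limit of > 100000 nM in this assay, at which 2 of the 4 values shown sit. On these data alone, it remains open whether the S drawing at this carbon keeps its advantage when ethoxycarbonyl gives way to a carboxylic acid, or when 4-methylbenzyl gives way to a longer chain ending in an amine.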